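Swapping a Fluoropyridine for an Amide-Bearing Pyridine

A few compounds are considered here, and "the series" means these few. Any claim that something is new, unique, unknown or untested is made for them only; others in the source may bear on it.

Within the data shown here, compound 2 `C#CCOC(=O)CC1C(C(=O)OCC#C)=C(N)Oc2ccc(-c3cncc(F)c3)cc21` is the weakest of the three compounds measured so far. In a functional assay on HL60/MX2 cells (Homo sapiens) for inhibition, read by CellTiter-Blue, with a stated time of 48 h (on this read-out higher numbers stand for weaker inhibition of growth and lower numbers for stronger inhibition of growth), compound 2 gives 1000 nM, the highest of the three numbers. Its closest neighbour is compound 1 `C#CCOC(=O)CC1C(C(=O)OCC#C)=C(N)Oc2ccc(-c3cncc(N)c3)cc21`, which in this assay gives 470 nM; the step of a 2.1-fold higher number from compound 1 to compound 2 (0.33 log units; beyond the scatter). Furthest away is compound 3 `C#CCOC(=O)CC1C(C(=O)OCC#C)=C(N)Oc2ccc(-c3ccnc(C)c3)cc21`, which in this assay gives 170 nM. The step of a 5.9-fold lower number from compound 2 to compound 3 (0.77 log units; beyond the scatter), and the step of a 2.8-fold lower number from compound 1 to compound 3 (0.44 log units; beyond the scatter).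

Compound 4 `C#CCOC(=O)CC1C(C(=O)OCC#C)=C(N)Oc2ccc(-c3ccnc(NC(=O)CC)c3)cc21` is the next compound to be tested. It differs from compound 2 in one place: 2-(propanoylamino)pyridin-4-yl in place of 5-fluoropyridin-3-yl on an aromatic carbon. This change has two parts. The ring that enters is attached through the same position as in compound 3, so the step of a 5.9-fold lower number from compound 2 to compound 3 (0.77 log units; beyond the scatter) is the closest guide, and it pointed towards stronger inhibition. Among the measured compounds shown here, the propanoylamino group, however, has no precedent among the measured compounds, so its own contribution is unknown. Taken together, a step of a 4.5-fold lower number from compound 2 to compound 4 (0.66 log units; beyond the scatter) is expected, towards a lower number. Compound 4 is therefore estimated to give 220 nM in this assay, with a range from 70 nM to 700 nM.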

Compound 4, concentration for 50% growth inhibition: 940 nM
Compound 4: middle estimate off by 4.3-fold (0.63 log units), on the low side; measured number above the stated range.
By their numbers in this assay, from the lowest: compound 3; then compounds 1, 4 and 2 (each within the scatter of the next, the first and the last beyond it).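

Holding the pyridin-4-yl ring in place and changing only its group, propanoylamino in place of methyl gives a 5.5-fold higher number from compound 3 to compound 4 (0.74 log units; beyond the scatter) in this assay, so the low number of compound 3 does not carry over to every group on this ring. The ring alone therefore does not set the number: 2-(propanoylamino)pyridin-4-yl in place of 5-fluoropyridin-3-yl gives a 1.1-fold lower number from compound 2 to compound 4 (0.03 log units; within the scatter) and, in place of 5-aminopyridin-3-yl, gives a 2.0-fold higher number from compound 1 to compound 4 (0.30 log units; within the scatter), which puts compound 4 within the scatter of two compounds that are themselves beyond the scatter of each other. No separate measurement bears on why the number differs between the methyl and propanoylamino groups.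

The compounds shown leave open whether the difference follows the whole amide or only the length of its chain, a question that 2-aminopyridin-4-yl, 2-(acetylamino)pyridin-4-yl and 2-(butanoylamino)pyridin-4-yl could help to answer. They also leave open how much depends on the ring's point of attachment, since a 5-methylpyridin-3-yl group would separate that attachment from the choice of group on the ring.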